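A Chain Exchange on a Well-Tolerated Compound

A few compounds are considered here, and "the series" means these few. Any claim that something is new, unique, unknown or untested is made for them only; others in the source may bear on it.

Measured in an ADME assay on Huh-7 cells (Homo sapiens) for cytotoxicity, with a stated time of 72 h; a lower number here means that less compound is tolerated, a higher number that more compound is tolerated:
- compound 1 `CC(C)CCn1nc(-c2cccs2)c(O)c(C2=NS(=O)(=O)c3cc(CS(C)(=O)=O)ccc3N2)c1=O`: > 33000 nM
- compound 2 `CCC(C)(C)Cn1nc(-c2cccs2)c(O)c(C2=NS(=O)(=O)c3cc(NS(C)(=O)=O)ccc3N2)c1=O`: > 1000 nM

Compound 2 stands at > 1000 nM, and this is a limit. Compound 1 stands at > 33000 nM, which is also a limit. Compound 3 `CCCC(C)n1nc(-c2cccs2)c(O)c(C2=NS(=O)(=O)c3cc(NS(C)(=O)=O)ccc3N2)c1=O` carries 1-methylbutyl in place of 2,2-dimethylbutyl on an aromatic nitrogen. Among the compounds with values here, no measured step gives the size of this change in this assay. The expected step that the limit leaves unreadable from compound 2 to compound 3 is upward, and it is counted from a limit rather than from a number. Compound 3 is estimated at 5000 nM, with an expected range of 1000 nM to 33000 nM.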

Compound 3, half-maximal cytotoxic concentration: > 33000 nM
Compound 3: only a limit was reported (the forecaster's own chance of this, stated with the estimate: 85%); middle value at least 6.6-fold (0.81 log units) away from the limit.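

Within the data shown here, the values of compound 2 and compound 3 in this assay are both limits, and no step between them can be read. The compounds shown leave open whether exchanging 2,2-dimethylbutyl for 1-methylbutyl changes the tolerated concentration at all.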